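The source may hold more compounds than are shown below. What is called first, only, known or untested is meant among the compounds shown, and "the series" means these compounds.

Working notes on a small set built on one shared core. Compound 1 `O=C1N(Cc2ccc(Cl)cc2Cl)c2cccn2S(=O)(=O)N1Cc1ccccc1`, compound 2 `O=C1N(Cc2ccccc2Br)c2cccn2S(=O)(=O)N1Cc1ccccc1` and compound 3 `O=C1N(Cc2ccccc2Br)c2cccn2S(=O)(=O)N1Cc1cccc(F)c1` carry measurements; compound 4 `O=C1N(Cc2ccc(Cl)cc2Cl)c2cccn2S(=O)(=O)N1Cc1cccc(F)c1` does not yet.

In an ADME assay on MT4 cells (Homo sapiens) for cytotoxicity, read by MTT assay, with a stated time of 5 days (on this read-out higher numbers stand for lower toxicity in this test and lower numbers for higher toxicity in this test), compound 2 gives 226000 nM. In this assay compound 1 gives 218000 nM. For compound 3 this assay reports only a limit, > 269000 nM, namely (the limit of > 269000 nM in this assay, at which 1 of the 3 values shown sits).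

The change from compound 2 to compound 1 is 2,4-dichlorophenyl in place of 2-bromophenyl on a saturated chain carbon bound to an amide-type nitrogen in a ring; the step is a 1.0-fold lower number from compound 2 to compound 1 (0.02 log units; within the scatter). The change from compound 2 to compound 3 is fluoro in place of hydrogen on an aromatic carbon; the step is an at least 1.1-fold higher number from compound 2 to compound 3 (0.07 log units; that floor lies within the scatter), read against a limit.

Compound 4 differs from compound 3 by 2,4-dichlorophenyl in place of 2-bromophenyl on a saturated chain carbon bound to an amide-type nitrogen in a ring, the same change as from compound 2 to compound 1, at the same place. In this assay the expected step is a step that the limit leaves unreadable from compound 3 to compound 4, resting on the measured 1.0-fold lower number from compound 2 to compound 1 (0.02 log units; within the scatter), which stayed within the scatter. Compound 4 is therefore estimated to give 270000 nM in this assay, with a range of 190000 nM to 380000 nM, and a further limit rather than a number is the more likely outcome.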

Compound 4, half-maximal cytotoxic concentration: > 249000 nM
Compound 4: no number, only a limit; the forecaster's own chance of this, stated with the estimate: 65%; the middle value lies beyond the limit too.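

The fluoro in place of hydrogen on an aromatic carbon can now be followed on two cores in this assay: the same change on two cores in this assay, an at least 1.1-fold higher number (0.07 log units; that floor lies within the scatter) from compound 2 to compound 3 and an at least 1.1-fold higher number (0.05 log units; that floor lies within the scatter) from compound 1 to compound 4; the limit leaves it open whether they differ

On the core of compound 1 the change gives an at least 1.1-fold higher number from compound 1 to compound 4 (0.05 log units; that floor lies within the scatter), while the step between compound 3 and compound 4 cannot be read. What carries over is only that the fluoro compound reads as a limit on both cores; neither the true size of either step nor whether the two steps are equal is shown.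

The compounds shown leave open whether the change would carry over in the same way to a core that gives numbers on both sides of the step. Also open, on these data alone, is whether an amine or a carboxylic acid in place of the fluoro, or a longer chain in place of the 2-bromobenzyl or 2,4-dichlorobenzyl, would give a number rather than a limit in this assay.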